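Amino for fluoro on the pyridinyl group of compound 3

The source may report more compounds than this note shows. Statements on the series, on what has been measured and on what is new or still open speak of the compounds shown alone.

Compound 3 `Nc1ccccc1NC(=O)c1ccc(NC(=O)NCc2ccc(F)nc2)cc1` gives 14000 nM in a functional assay on HCT-116 cells (Homo sapiens) for cytotoxicity, read by MTT assay, with a stated time of 72 h (on this read-out higher numbers stand for weaker inhibition and lower numbers for stronger inhibition), the highest of the three numbers measured. Compound 2 `Cc1ccc(CNC(=S)Nc2ccc(C(=O)Nc3ccccc3N)cc2)cn1` gives 11000 nM, which lies within the scatter of compound 3. Within the data shown here, compound 1 `Nc1ccccc1NC(=O)c1ccc(NC(=O)NCc2ccc(Cl)nc2)cc1` gives 5200 nM, and the step of a 2.7-fold higher number from compound 1 to compound 3 (0.43 log units; beyond the scatter) is the only measured change at the position now in question. Compound 4 `Nc1ccc(CNC(=O)Nc2ccc(C(=O)Nc3ccccc3N)cc2)cn1` carries amino in place of fluoro on an aromatic carbon. Among the measured compounds shown here, the one measured step at that position, a 2.7-fold higher number from compound 1 to compound 3 (0.43 log units; beyond the scatter), was modest, and no measured pair shows an amino group entering anywhere, so the direction of the new step cannot be read from the data. The expected step of a 1.4-fold lower number from compound 3 to compound 4 (0.15 log units; within the scatter) is therefore small, with a wide range either way around the number of compound 3. Compound 4 is estimated at 10000 nM, with a range from 3500 nM to 30000 nM.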

Compound 4, half-maximal inhibitory concentration: 7300 nM
Compound 4: the middle estimate sits 1.4-fold (0.14 log units) above what was measured, within the range that was stated.
By their numbers in this assay, from the lowest: compounds 1, 4, 2 and 3 (each within the scatter of the next, the first and the last beyond it).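

In this assay, the amino group at this place gives a 1.9-fold lower number from compound 3 to compound 4 (0.28 log units; within the scatter) and a 1.4-fold higher number from compound 1 to compound 4 (0.15 log units; within the scatter), so neither step separates it from the group it replaces. The earlier step of a 2.7-fold higher number from compound 1 to compound 3 (0.43 log units; beyond the scatter) did separate chloro from fluoro, and the new result places amino within the scatter of both, with its added hydrogen-bond donor and acceptor giving no step beyond the scatter in this read-out. Nothing at hand gives a measured basis for explaining these numbers.

The compounds shown leave open whether a dimethylamino or methoxy group on this carbon would stand apart from amino, fluoro or chloro. They also leave open whether amino would give similar steps on the thiourea linker of compound 2, which differs from compound 4 in more than one place.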